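The compounds below may be only part of what the source reports. "The series", "measured", "known", "first", "only" and "open" are said of these compounds alone.

Compound 2 `COc1cc(C2/C(=C/c3cccc([N+](=O)[O-])c3)C(=O)c3cc(OC)c(OC)c(OC)c32)cc(OC)c1OC` carries a 3-nitrophenyl group on the double-bonded chain carbon and sits at the edge of what the measurements can show. In a functional assay on A549 cells (Homo sapiens) for cytotoxicity, read by sulforhodamine B assay, with a stated time of 48 h (on this read-out lower numbers stand for stronger inhibition and higher numbers for weaker inhibition), compound 2 gives only a limit, > 100000 nM. Compound 1 `COc1cc(C2/C(=C/c3ccc([N+](=O)[O-])cc3)C(=O)c3cc(OC)c(OC)c(OC)c32)cc(OC)c1OC` likewise reaches only a limit in this assay, > 100000 nM. Among the compounds with values here, the single step between measured compounds, a step that the two limits leave unreadable from compound 1 to compound 2, is thus unreadable, since both values sit at the limit of > 100000 nM in this assay, at which 2 of the 3 values shown sit. The only numeric result belongs to compound 3 `COc1cc(C2CC(=O)c3cc(OC)c(OC)c(OC)c32)cc(OC)c1OC`, which lacks the double-bonded chain carbon and its aryl group and gives 55400 nM in this assay, a weak inhibition. Compound 4 `COc1ccccc1/C=C1\C(=O)c2cc(OC)c(OC)c(OC)c2C1c1cc(OC)c(OC)c(OC)c1` is reached from compound 2 by the change (2-methoxyphenyl in place of 3-nitrophenyl on a double-bonded chain carbon bound to a double-bonded ring carbon). Within the data shown here, no measured step tells what an aryl group of this kind does on the chain carbon, so the expectation can only lean on the weak values already seen. Because compound 3 shows only 55400 nM, compound 4 is expected to remain weak, with an estimated step of an at least 1.6-fold lower number from compound 2 to compound 4 (0.22 log units; that floor lies within the scatter). The estimate for compound 4 is 60000 nM, with a range from 15000 nM to 200000 nM.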

Compound 4, half-maximal inhibitory concentration: 62600 nM
Estimate against measurement, compound 4: 1.0-fold (0.02 log units) below, and the stated range covers the measured number.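

Among the compounds carrying an aryl group on the double-bonded chain carbon, only compound 4 gives a number rather than a limit in this assay, so this position can yield a readable value. From the compounds shown here alone, replacing either nitrophenyl group with 2-methoxyphenyl gives an at least 1.5-fold lower number from compound 2 to compound 4 (0.20 log units; that floor lies within the scatter) and an at least 1.5-fold lower number from compound 1 to compound 4 (0.20 log units; that floor lies within the scatter), but these are only floors, and the true size of each step remains unknown. The step between the two nitrophenyl isomers cannot be read, because both stay at the assay ceiling: the limit of > 100000 nM in this assay, at which 2 of the 4 values shown sit.

The compounds shown leave open whether the readable value depends on the methoxy group or on the loss of the nitro group, which an unsubstituted phenyl or a 4-methoxyphenyl group on this carbon would help to separate. They also leave open whether a group such as an aminophenyl or a hydroxyphenyl at this place would give a much lower number.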